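Working notes: from compound 2 to compound 4

This account rests on a few compounds, and the source may have more. Where it says the series, first, only, none or still open, it means among the compounds named here.

Measured so far in a functional assay on SK-OV-3 cells (Homo sapiens) for antiproliferative activity, read by MTT assay, with a stated time of 72 h (on this read-out lower numbers stand for stronger inhibition and higher numbers for weaker inhibition), on these compounds:
- compound 1 `Cc1cc(C)c(NC(=O)CCc2cccc3c2B(O)OC3)c(C)c1` gives 19000 nM
- compound 2 `O=C(CCc1cccc2c1B(O)OC2)Nc1cccc(-c2cccc(Cl)c2)c1` gives 300 nM
- compound 3 `O=C(CCc1cccc2c1B(O)OC2)Nc1cccc(-c2cccc(OC(F)(F)F)c2)c1` gives 460 nM

Compound 2 and compound 3 sit within the scatter of each other at the low end of these numbers, while compound 1 stands well above both. Compound 4 `O=C(CCc1cccc2c1B(O)OC2)Nc1cccc(-c2ccc(C(F)(F)F)cc2)c1` is not yet measured and departs from compound 2 by 4-(trifluoromethyl)phenyl in place of 3-chlorophenyl on an aromatic carbon on an aromatic carbon. Among the measured compounds shown here, the one measured step that bears on this is a 1.5-fold higher number from compound 2 to compound 3 (0.19 log units; within the scatter) for trifluoromethoxy in place of chloro, and it stays within the scatter. For the measured compounds named here, no measured compound carries the 4-(trifluoromethyl)phenyl group, so the range is kept wide. In this assay no step beyond the scatter is expected, with a slight lean towards a higher number. The step expected is a 1.5-fold higher number from compound 2 to compound 4 (0.18 log units; within the scatter) on this estimate. Compound 4 is expected at 450 nM with a range from 170 nM to 1200 nM as an estimate.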

Compound 4, half-maximal inhibitory concentration: 500 nM
Beside the measured number, compound 4's estimate is 1.1-fold (0.05 log units) below it, within the range that was stated.
By their numbers in this assay, from the lowest: compounds 2, 3 and 4 (each within the scatter of the next); then compound 1.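

In this assay, 4-(trifluoromethyl)phenyl in place of 3-chlorophenyl gives a 1.7-fold higher number from compound 2 to compound 4 (0.22 log units; within the scatter). Unlike the earlier step, which exchanged only chloro for trifluoromethoxy, this change replaces the whole aryl group, and the number still stays within the scatter. No measurement shown here bears on the reason for this result.

This single change alters both the group on the outer ring and where it sits, and the two cannot be told apart here. As far as these compounds go, how an amine or a carboxylic acid on that ring would read remains open.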